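Coumarin-triazole dienone hybrids: moving to a naphthalene end

The source may report more compounds than this note shows. Statements on the series, on what has been measured and on what is new or still open speak of the compounds shown alone.

Going by the values given here, compound 1 `COc1ccccc1/C=C/C(=O)/C=C/c1ccc(OCc2cn(CCOc3cc(=O)oc4ccccc34)nn2)c(OC)c1` is the only member of this set with a number: in a functional assay on PC-3 cells (Homo sapiens) for inhibition, read by sulforhodamine B assay, with a stated time of 48 h, tested at 50 uM (on this read-out lower numbers stand for less inhibition of growth and higher numbers for more inhibition of growth at the one concentration tested), compound 1 gives 11%. Compound 2 `COc1ccccc1/C=C/C(=O)/C=C/c1ccc(OCc2cn(CCCCOc3cc(=O)oc4ccccc34)nn2)c(OC)c1`, which differs in the linker length, is reported in this assay only as "not active" (no number reported). Among the compounds with values here, compound 3 `COc1cc(/C=C/C(=O)/C=C/c2cc(OC)c(OC)c(OC)c2)ccc1OCc1cn(CCCCCOc2cc(=O)oc3ccccc23)nn1` likewise carries no single number in this assay, being reported as "not active" (no number reported), so compound 3 stands, with compound 2, among the entries without a value, and no step to it can be sized. Compound 4 `COc1cc(/C=C/C(=O)/C=C/c2cccc3ccccc23)ccc1OCc1cn(CCCCCOc2cc(=O)oc3ccccc23)nn1` is the untested variant, with the change (naphthalen-1-yl in place of 3,4,5-trimethoxyphenyl on a double-bonded chain carbon bound to a double-bonded chain carbon). Within the data shown here, with no measured step available, the expected movement in this assay is none beyond the scatter, with little growth inhibition. Compound 4 is therefore estimated at 10%, in the range 0% to 30%.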

Compound 4, percent growth inhibition at one concentration: "not active" (no number reported)
No number was reported for compound 4; there is nothing to compare the estimate with.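

Compound 3 and compound 4 are both reported only as "not active", so no step can be read from this change, and no supporting evidence bears on the result. In this assay, on these data alone, the effect of replacing 3,4,5-trimethoxyphenyl with naphthalen-1-yl stays open.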